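The compounds below may be only part of what the source reports. "The series", "measured", "known", "first", "only" and "open" are said of these compounds alone.

Measured so far:
compound 1, `COc1cccc(S(=O)(=O)c2ccc3c(c2)CCC[C@H]3CN)c1`, 0.398 nM
compound 2, `NC[C@@H]1CCCc2cc(S(=O)(=O)c3cccc(F)c3)ccc21`, 0.0794 nM
compound 3, `NC[C@@H]1CCCc2cc(S(=O)(=O)c3cn[nH]c3)ccc21`, 2 nM

In an assay on isolated protein for displacement of a labelled ligand from 5-hydroxytryptamine receptor 6 (Homo sapiens) (on this read-out higher numbers stand for weaker inhibition and lower numbers for stronger inhibition), compound 2 stands lowest of the three numbers. Its nearest neighbour is compound 1, and a 5.0-fold lower number from compound 1 to compound 2 (0.70 log units; beyond the scatter) separates the two; the furthest is compound 3, reached by a 25-fold higher number from compound 2 to compound 3 (1.40 log units; beyond the scatter). Both of these measured steps concern the group on the sulfonyl sulfur and leave the aminomethyl side of the shared core untouched.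

Compound 4, `CN(C[C@@H]1CCCc2cc(S(=O)(=O)c3cccc(F)c3)ccc21)S(N)(=O)=O`, differs from compound 2 in exactly that untouched part: methyl(sulfamoyl)amino in place of amino on a saturated chain carbon bound to a saturated ring carbon. Among the measured compounds shown here, no measured step bears on this change, so the two known steps give its size only as a reminder that changes elsewhere on this core moved the number by modest to large amounts. The expectation for compound 4 therefore rests on the value of compound 2 alone and carries a wide range. Compound 4 is estimated at 5 nM, between 0.5 nM and 50 nM, which means an expected 63-fold higher number from compound 2 to compound 4 (1.80 log units; beyond the scatter).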

Compound 4, inhibition constant: 3.98 nM
The estimate for compound 4 lay 1.3-fold (0.10 log units) above the measured number, and the stated range covers the measured number.
By their numbers in this assay, from the lowest: compound 2; then compound 1; then compounds 3 and 4 (each within the scatter of the next).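

Among the compounds shown here, the aminomethyl side of the shared core, untouched by the earlier steps, proves to be a position where the number in this assay moves substantially: methyl(sulfamoyl)amino in place of amino on a saturated chain carbon bound to a saturated ring carbon gives a 50-fold higher number from compound 2 to compound 4 (1.70 log units; beyond the scatter), a large step. Compound 4 still gives 3.98 nM, so a measurable number survives the loss of the amino group at this position. No measurement shown here accounts for the size of this step.

The compounds shown leave open how much of the step belongs to the methyl and how much to the sulfamoyl part, which a methylamino or an acetamido group on the same carbon could separate. They also leave open whether the step keeps its size with 1H-pyrazol-4-yl on the sulfonyl sulfur.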